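Little Shift Expected From 1-Phenylethyl to 4-Methoxyphenyl

The source may hold more compounds than are shown below. What is called first, only, known or untested is meant among the compounds shown, and "the series" means these compounds.

In a physicochemical assay for solubility, read by HPLC, in phosphate buffer, with a stated time of 24 h, at pH 7.4, tested at 100 uM (on this read-out higher numbers stand for higher solubility and lower numbers for lower solubility), compound 1 (`O=C(CCCCNc1c(Nc2ccccc2)c(=O)c1=O)NO`) gives 87000000 nM and compound 2 (`C[C@@H](Nc1c(NCCCCCC(=O)NO)c(=O)c1=O)c1ccccc1`) gives 80000000 nM while compound 3 (`Cc1ccc([C@H](C)Nc2c(NCCCCCC(=O)NO)c(=O)c2=O)cc1`) gives 76000000 nM in the same test. Compound 2 therefore sits within the scatter of both others, and the three values cannot be ranked. Compound 4 (`COc1ccc(Nc2c(NCCCCCC(=O)NO)c(=O)c2=O)cc1`) is still unmeasured and carries 4-methoxyphenyl in place of 1-phenylethyl on a nitrogen on an aromatic ring. Within the data shown here, no measured step covers this change, so in this assay no shift beyond the scatter is expected in either direction. This expectation rests on compound 1 at 87000000 nM and compound 2 at 80000000 nM lying within the scatter of each other. The estimated step runs a 1.1-fold lower number from compound 2 to compound 4 (0.03 log units; within the scatter) and stays within the scatter. Compound 4 is expected at 75000000 nM within an estimated range of 40000000 nM to 100000000 nM in this test.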

Compound 4, solubility: 3300000 nM
Estimate against measurement, compound 4: 23-fold (1.36 log units) above; the whole stated range lies above it.
By their numbers in this assay, from the lowest: compound 4; then compounds 3, 2 and 1 (each within the scatter of the next).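

In this assay, among these compounds, the group on this nitrogen proves able to move the number: 4-methoxyphenyl in place of 1-phenylethyl gives a 24-fold lower number from compound 2 to compound 4 (1.38 log units; beyond the scatter) and so opens a gap that the earlier compounds, all within the scatter of one another, did not show. Both groups have the same heavy-atom count, so that count alone does not set the value here. Nothing given here accounts for the step.

The compounds shown leave open whether the lower number goes with the methoxy group or with the loss of the 1-phenylethyl carbon chain link. A 1-(4-methoxyphenyl)ethyl group on this nitrogen would separate the two.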